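Trading a Ring for a Chain at the Aryl Ether

The source may hold more compounds than are shown below. What is called first, only, known or untested is meant among the compounds shown, and "the series" means these compounds.

Two compounds sharing one core were tested in an assay on isolated protein for antagonist activity at advanced glycosylation end product-specific receptor (Homo sapiens), read by ELISA, with a stated time of 60 min, tested at 10 uM; a higher number here means more inhibition at the concentration tested (going by the name of the read-out), a lower number less inhibition. Compound 1 `CCCCc1sc(C(=O)Nc2ccc(OCCCN(CC)CC)cc2)nc1-c1ccc(Oc2ccc(Cl)cc2)cc1` gives 48.1%. Compound 2 `CCCCc1sc(-c2ccc(OCC3CCCN(CC)C3)cc2)nc1-c1ccc(Oc2ccc(Cl)cc2)cc1` gives 58%, the higher of the two numbers, although its gap to compound 1 lies within the usual scatter, so no order can be read from it. Compound 3 `CCCCc1sc(-c2ccc(OCCCN(C)C)cc2)nc1-c1ccc(Oc2ccc(Cl)cc2)cc1` carries 2-(dimethylamino)ethyl in place of 1-ethylpiperidin-3-yl on a saturated chain carbon bound to an oxygen on an aromatic ring. Within the data shown here, no measured pair shows what such a change does here, so only a small step is expected, a number 8 percentage points lower from compound 2 to compound 3 (within the scatter), not beyond the scatter. Compound 3 is expected to give about 50% in this assay, within 30% to 70%.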

Compound 3, a percentage reported as inhibition, at one concentration (the size of the read-out at that concentration, not a potency): 46.2%
The estimate for compound 3 lay 3.8 percentage points above the measured number, and the stated range covers the measured number.
By their numbers in this assay, from the lowest: compounds 3, 1 and 2 (each within the scatter of the next, the first and the last beyond it).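

In this assay, replacing 1-ethylpiperidin-3-yl with the open-chain 2-(dimethylamino)ethyl gives a number 11.8 percentage points lower from compound 2 to compound 3 (beyond the scatter), so at this position the two groups are not interchangeable. The change removes the ring and also goes from 8 heavy atoms to 5, and this single step cannot separate the two. Nothing measured here gives a reason for the drop. Still open, on these data alone, is whether the ring itself or the extra heavy atoms matter more. A 2-(diethylamino)ethyl group at the same place would bear on that question.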